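Swapping the Benzylamino Group for Hydroxymethyl

The source may hold more compounds than are shown below. What is called first, only, known or untested is meant among the compounds shown, and "the series" means these compounds.

Compound 1 `COc1cc(Oc2cccc(Nc3ccccc3)c2)cc(OC)c1CNCc1ccccc1`: 7490 nM
Compound 2 `CCN1CCN(Cc2c(OC)cc(Oc3cccc(Nc4ccccc4)c3)cc2OC)CC1`: a limit, > 20000 nM

In a functional assay on SW-620 cells (Homo sapiens) for inhibition, read by MTT assay, with a stated time of 72 h (a lower number here means a stronger inhibitor, a higher number a weaker inhibitor), compound 1 gives 7490 nM, the only plain number shown. Compound 2 reaches only a limit, sitting at the limit of > 20000 nM in this assay, at which 1 of the 2 values shown sits. Compound 3 `COc1cc(Oc2cccc(Nc3ccccc3)c2)cc(OC)c1CCO` differs from compound 1 in one place: hydroxymethyl in place of benzylamino on a saturated chain carbon bound to an aromatic carbon. Going by the values given here, the one measured step at this place is an at least 2.6-fold higher number from compound 1 to compound 2 (0.42 log units; beyond the scatter), where the benzylamino group also left the saturated chain carbon bound to an aromatic carbon. Compound 3 is therefore expected to be weaker, with a step of a 2.4-fold higher number from compound 1 to compound 3 (0.38 log units; beyond the scatter). The estimate for compound 3 is 18000 nM, between 6000 nM and 50000 nM.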

Compound 3, half-maximal inhibitory concentration: > 20000 nM
Compound 3 ended at the assay's limit; the forecaster's own chance of this, stated with the estimate: 45%; middle value at least 1.1-fold (0.04 log units) from the limit.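

In this assay, hydroxymethyl in place of benzylamino on the saturated chain carbon bound to an aromatic carbon gives an at least 2.6-fold higher number from compound 1 to compound 3 (0.42 log units; beyond the scatter) and so shows that a second replacement, this one without a ring, also falls short of compound 1. Compound 2 and compound 3 now both stand at a limit, and the step between them cannot be read: the limit of > 20000 nM in this assay, at which 2 of the 3 values shown sit. The compounds shown leave open whether a smaller amine such as dimethylamino, or a carboxylic acid on a longer chain, would match compound 1 at this place.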